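Iodine removal on a fused quinazoline-type thioether series

The source may report more compounds than this note shows. Statements on the series, on what has been measured and on what is new or still open speak of the compounds shown alone.

Three compounds have numbers in a functional assay on PC-3 cells (Homo sapiens) for antiproliferative activity, read by MTT assay; a higher number here means a weaker inhibitor, a lower number a stronger inhibitor. Compound 1 `COc1cc(-c2nnc(Sc3ncnc4ccc(I)cc34)o2)cc(OC)c1OC` gives 8900 nM, compound 3 `COc1cc(-c2nnc(Sc3ncnc4ccccc34)o2)cc(OC)c1OC` gives 5600 nM, and compound 2 `C=CCSc1ncnc2ccc(I)cc12` gives 28800 nM, the highest of the three. The change from compound 1 to compound 3 is hydrogen in place of iodo on an aromatic carbon, and the step is a 1.6-fold lower number from compound 1 to compound 3 (0.20 log units; within the scatter). Compound 4 `C=CCSc1ncnc2ccccc12` carries the same change relative to compound 2: hydrogen in place of iodo on an aromatic carbon. The difference between the cores of compound 1 and compound 2 is not broken down here. Because the same change gave a 1.6-fold lower number from compound 1 to compound 3 (0.20 log units; within the scatter), a step of similar size is expected here, namely a 1.6-fold lower number from compound 2 to compound 4 (0.20 log units; within the scatter). The number expected for compound 4 in this assay is therefore 18000 nM, with a likely range from 8000 nM to 45000 nM.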

Compound 4, half-maximal inhibitory concentration: 48000 nM
Estimate against measurement, compound 4: 2.7-fold (0.43 log units) below; the whole stated range lies below it.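

In this assay, hydrogen in place of iodo on an aromatic carbon gives a 1.7-fold higher number from compound 2 to compound 4 (0.22 log units; within the scatter). Set beside the earlier step, the two cores do not separate on this change, and on both it stays within the scatter: the same change on two cores in this assay, a 1.6-fold lower number (0.20 log units; within the scatter) from compound 1 to compound 3 and a 1.7-fold higher number (0.22 log units; within the scatter) from compound 2 to compound 4, 2.6-fold (0.42 log units) apart, within the scatter of two such steps. The change can therefore be carried between these two cores as a small step of no fixed direction, but two cores say nothing about a third, and steps this small do not show that the group at this place never matters.

Going by these compounds, only iodo and hydrogen appear at this place, so a chloro group, a methoxy group or an amine there remains open. Also open, on these data alone, is how a longer chain in place of the allyl group would read.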